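The source may report more compounds than this note shows. Statements on the series, on what has been measured and on what is new or still open speak of the compounds shown alone.

Working notes on the series. Compound 1 `O=C(Nc1ccccc1)Nc1ccc(OCc2nc3ccccc3s2)cc1` gives 420 nM in an assay on isolated protein for inhibition of Polyunsaturated fatty acid 5-lipoxygenase (Homo sapiens), read by HPLC, with a stated time of 10 min; on this read-out lower numbers stand for stronger inhibition and higher numbers for weaker inhibition. For the measured compounds named here, compound 2 `O=C(Nc1ccc(OCc2nc3ccccc3s2)cc1)Nc1cccc(Cl)c1` gives 170 nM in this assay, the lowest of the two numbers so far, with compound 1 nearest. Going by the values given here, the only measured step, a 2.5-fold lower number from compound 1 to compound 2 (0.39 log units; beyond the scatter), came with chloro in place of hydrogen on an aromatic carbon. Compound 3 `O=C(Nc1ccc(OCc2nc3ccccc3s2)cc1)Nc1cc(Cl)cc(Cl)c1` differs from compound 2 by chloro in place of hydrogen on an aromatic carbon. That earlier step bears directly on this one, though a second chloro on a ring that already carries one is expected to add less than the first. For compound 3 a step of a 1.5-fold lower number from compound 2 to compound 3 (0.19 log units; within the scatter) is expected. Compound 3 is estimated at 110 nM, range 50 nM to 250 nM.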

Compound 3, half-maximal inhibitory concentration: 90 nM
The estimate for compound 3 lay 1.2-fold (0.09 log units) above the measured number; the measured number falls inside the stated range.
By their numbers in this assay, from the lowest: compounds 3 and 2 (each within the scatter of the next); then compound 1.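

The second chloro, 3-chlorophenyl to 3,5-dichlorophenyl, gives a 1.9-fold lower number from compound 2 to compound 3 (0.28 log units; within the scatter), so at this place on the ring compound 3 cannot be told apart from compound 2. Only the whole change, 3,5-dichlorophenyl in place of phenyl, separates clearly, with a 4.7-fold lower number from compound 1 to compound 3 (0.67 log units; beyond the scatter). Nothing measured here gives a reason for either step.

Still open, as far as these compounds go, is whether a methoxy group, an amine or a carboxylic acid in place of the chloro on this ring would give a number beyond the scatter of compound 3.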